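A few compounds are considered here, and "the series" means these few. Any claim that something is new, unique, unknown or untested is made for them only; others in the source may bear on it.

In an in vitro ADME assay on microsomes from liver (Homo sapiens) for pharmacokinetics, read by LC-MS, with a stated time of 10 min, tested at 1 uM (a lower number here means slower removal, a higher number faster removal of the compound), three compounds sharing one core have been measured. Compound 1 `CN1C[C@H](C(=O)Nc2ccc(F)cc2)[C@@H](c2ccc(/C=C/C(=O)Nc3ccccc3N)cc2)C1` gives 5 mL/min/kg, compound 2 `CN1C[C@H](C(=O)Nc2ccc(C#N)cc2)[C@@H](c2ccc(/C=C/C(=O)Nc3ccccc3N)cc2)C1` gives 1 mL/min/kg, and compound 3 `Cc1cc(NC(=O)[C@H]2CN(C)C[C@@H]2c2ccc(/C=C/C(=O)Nc3ccccc3N)cc2)ccc1F` gives 15 mL/min/kg, the highest of the three. Compound 4 `CN1C[C@H](C(=O)Nc2ccc(Cl)cc2F)[C@@H](c2ccc(/C=C/C(=O)Nc3ccccc3N)cc2)C1` differs from compound 3 in one place, on the amide-type nitrogen: 4-chloro-2-fluorophenyl in place of 4-fluoro-3-methylphenyl on an amide-type nitrogen. Within the data shown here, two measured steps bear on this change. Methyl in place of hydrogen on an aromatic carbon went with a 3.0-fold higher number from compound 1 to compound 3 (0.48 log units; beyond the scatter), a modest rise, and compound 4 has no such methyl. Swapping the whole group on that nitrogen gave a 15-fold higher number from compound 2 to compound 3 (1.18 log units; beyond the scatter), a large step, so this spot can matter. Among the measured compounds shown here, no measured compound carries chloro, which leaves the outcome uncertain. A modest fall in this assay is expected, a 2.5-fold lower number from compound 3 to compound 4 (0.40 log units; beyond the scatter). For compound 4 the estimated value is 6 mL/min/kg, with an expected range of 2 mL/min/kg to 18 mL/min/kg.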

Compound 4, clearance: 11 mL/min/kg
Compound 4: the middle estimate sits 1.8-fold (0.26 log units) below what was measured, and the stated range covers the measured number.
By their numbers in this assay, from the lowest: compound 2; then compound 1; then compounds 4 and 3 (each within the scatter of the next).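

In this assay, a chloro-bearing group with no methyl, 4-chloro-2-fluorophenyl, replaces 4-fluoro-3-methylphenyl on the amide-type nitrogen and gives a 1.4-fold lower number from compound 3 to compound 4 (0.13 log units; within the scatter), so among these compounds the methyl is not required for a number at this level. The same group still separates from the other two, with a 2.2-fold higher number from compound 1 to compound 4 (0.34 log units; beyond the scatter) and an 11-fold higher number from compound 2 to compound 4 (1.04 log units; beyond the scatter), which shows that the 4-cyanophenyl and 4-fluorophenyl compounds stay apart from it. Nothing available explains these steps. Still open, on these data alone, is how 4-chlorophenyl, with no second fluorine, would compare, and whether an amine or a carboxylic acid on this ring would fall nearer compound 2 or compound 4.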